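The compounds below may be only part of what the source reports. "The series", "measured", "known", "first", "only" and "open" are said of these compounds alone.

Measured compounds in a functional assay on BJAB cells (Homo sapiens) for antiproliferative activity, with a stated time of 4 days; on this read-out higher numbers stand for an effect only at larger amounts of compound and lower numbers for an effect already at smaller amounts:

Compound 1 `Cc1nn(-c2nc(-c3ccc(Cl)c(Cl)c3)c(SC(C)C)s2)c(C(=O)O)c1-c1cnn(C)c1` gives 6800 nM.
Compound 2 `Cc1nn(-c2nc(-c3ccc(Cl)c(Cl)c3)c(SC(C)C)s2)c(C(=O)O)c1-c1ccncc1` gives 5900 nM.
Compound 3 `Cc1nn(-c2nc(-c3ccc(Cl)c(Cl)c3)c(SC(C)C)s2)c(C(=O)O)c1-c1cccc(C(F)(F)F)c1` gives 22000 nM.

Compound 3 stands highest of the three numbers. Its nearest neighbour is compound 1, the step being a 3.2-fold higher number from compound 1 to compound 3 (0.51 log units; beyond the scatter); the step of a 3.7-fold higher number from compound 2 to compound 3 (0.57 log units; beyond the scatter) is slightly larger. Compound 1 and compound 2 differ only by a 1.2-fold lower number from compound 1 to compound 2 (0.06 log units; within the scatter), so those two cannot be ordered.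

Compound 4 `Cc1cccc(-c2c(C)nn(-c3nc(-c4ccc(Cl)c(Cl)c4)c(SC(C)C)s3)c2C(=O)O)c1` is not yet measured. It differs from compound 3 as follows: methyl in place of trifluoromethyl on an aromatic carbon. The two groups share the same place on the same ring.

None of the three measured steps bears directly on this change: each of them exchanges the whole ring that hangs from the shared core, and none alters a single group on a ring that stays. The only fixed point is that compound 3, with the trifluoromethyl-bearing ring, gives the highest number in this assay, and that the exchanges reaching it were of modest size. Going by the values given here, with no precedent for trifluoromethyl against methyl on that ring, the step of a 1.2-fold lower number from compound 3 to compound 4 (0.09 log units; within the scatter) is expected to stay within the scatter, in no assured direction. Compound 4 is therefore estimated at 18000 nM, within 6000 nM to 50000 nM.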

Compound 4, half-maximal effective concentration: 17000 nM
Estimate against measurement, compound 4: 1.1-fold (0.02 log units) above; the range from low to high includes it.
By their numbers in this assay, from the lowest: compounds 2 and 1 (each within the scatter of the next); then compounds 4 and 3 (each within the scatter of the next).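

Read in this assay, this is the first change that keeps the ring and alters only the group on it, and the step from trifluoromethyl to methyl (a 1.3-fold lower number from compound 3 to compound 4 (0.11 log units; within the scatter)) stays within the scatter, so the two groups cannot be told apart in this place on the six-membered aromatic ring of carbon only. The higher number of compound 3 is therefore not peculiar to trifluoromethyl: 3-methylphenyl stands apart from both pyridin-4-yl (a 2.9-fold higher number from compound 2 to compound 4 (0.46 log units; beyond the scatter)) and 1-methyl-1H-pyrazol-4-yl (a 2.5-fold higher number from compound 1 to compound 4 (0.40 log units; beyond the scatter)) by modest steps beyond the scatter, much like those printed for 3-(trifluoromethyl)phenyl (a 3.7-fold higher number from compound 2 to compound 3 (0.57 log units; beyond the scatter); a 3.2-fold higher number from compound 1 to compound 3 (0.51 log units; beyond the scatter)). No measurement at hand accounts for either the match between the two groups or the gap to the other two rings.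

Open, from the compounds shown here alone, is whether the number on this ring responds to any group in this place, for instance an amine, a hydroxyl, a nitrile or a longer chain such as propyl. Also open, going by these compounds, is how a plain phenyl ring, carrying no group at all, compares with 3-methylphenyl and with pyridin-4-yl.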